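A few compounds are considered here, and "the series" means these few. Any claim that something is new, unique, unknown or untested is made for them only; others in the source may bear on it.

Measured so far:
- Compound 1, `O=C(Oc1ccccc1)N1CCC(CCn2ccc3cc(F)ccc32)CC1`: 130 nM
- Compound 2, `O=C(Oc1ccccc1)N1CCC(CCCn2ccc3ccccc32)CC1`: 570 nM

Both compounds were tested in an assay on microsomes from brain for inhibition of Fatty-acid amide hydrolase 1 (Rattus norvegicus), read by HPLC, with a stated time of 60 min; on this read-out lower numbers stand for stronger inhibition and higher numbers for weaker inhibition. Compound 1 has the lowest of the two numbers; compound 2 sits at a higher number, and the gap between the two lies beyond the usual scatter. The two compounds differ in more than one place, so no single structural change can be read from that gap.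

Compound 3, `O=C(Oc1ccccc1)N1CCC(CCn2ccc3ccccc32)CC1`, has not yet been measured in this assay. It differs from compound 1 by hydrogen in place of fluoro on an aromatic carbon. Compound 2 already shows what an unsubstituted version of the core gives, though with a longer chain, which leaves the effect of the fluoro alone uncertain. A modest step is expected from compound 1 to compound 3, most likely toward a somewhat higher number, but it may well stay within the scatter. Compound 3 is therefore estimated at 220 nM, with a range of 70 nM to 650 nM, which corresponds to an expected step of a 1.7-fold higher number from compound 1 to compound 3 (0.23 log units; within the scatter).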

Compound 3, half-maximal inhibitory concentration: 110 nM
Estimate against measurement, compound 3: 2.0-fold (0.30 log units) above; low and high end bracket the measured number.
By their numbers in this assay, from the lowest: compounds 3 and 1 (each within the scatter of the next); then compound 2.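

Replacing the fluoro with hydrogen on this aromatic carbon gives a 1.2-fold lower number from compound 1 to compound 3 (0.07 log units; within the scatter) in this assay and so does not shift the number beyond the usual scatter. At this position, then, the fluoro is not needed for the inhibition seen with compound 1, since compound 3 reads the same within the scatter without it. This single pair shows only that these two small substituents cannot be told apart here, not that the position would accept any group.

Still open, from the compounds shown here alone, is whether a larger or different group on this carbon, such as chloro, methoxy, nitrile or an amine, would move the number beyond the scatter. Also open, going by these compounds, is whether a fluoro on another carbon of the same ring would behave as this one does. Nothing measured here gives a reason why the fluoro and the hydrogen read alike.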